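Capping an oxime hydroxyl with a cyanomethyl group

The source may report more compounds than this note shows. Statements on the series, on what has been measured and on what is new or still open speak of the compounds shown alone.

Compound 1, with the structure `CO[C@]1(c2cc(F)cc(S(=O)(=O)c3ccc(/C(C)=N/O)cc3)c2)CCO[C@@H](C)C1`, is the more potent of the two measured compounds. In a functional assay (blood) for inhibition, with Homo sapiens as the target (on this read-out higher numbers stand for weaker inhibition and lower numbers for stronger inhibition), compound 1 gives 20 nM. Going by the values given here, compound 2, with the structure `C/C(=N\OCc1ccncc1)c1ccc(Sc2cc(F)cc(C3CCOCC3)c2)cc1`, is the only neighbour on the scale; in this assay compound 2 gives 300 nM, a much weaker result that lies well beyond the scatter. Compound 2 differs from compound 1 in several places at once, so its number says little about any single change.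

Compound 3, with the structure `CO[C@]1(c2cc(F)cc(S(=O)(=O)c3ccc(/C(C)=N/OCC#N)cc3)c2)CCO[C@@H](C)C1`, has not yet been measured. It differs from compound 1 in one place: cyanomethyl in place of hydrogen on an oxygen. The free hydroxyl of the oxime in compound 1 thus becomes a cyanomethoxy group in compound 3.

Among the compounds with values here, no measured pair shows this change on its own, so the expectation rests on the shared core and on the single difference. A small weakening is expected, roughly a 2.0-fold higher number from compound 1 to compound 3 (0.30 log units; within the scatter), because compound 1 already sits at 20 nM and the added group is small. Compound 3 is expected to give about 40 nM in this assay, within a range from 10 nM to 160 nM.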

Compound 3, half-maximal inhibitory concentration: 60 nM
Beside the measured number, compound 3's estimate is 1.5-fold (0.18 log units) below it; the range from low to high includes it.
By their numbers in this assay, from the lowest: compound 1; then compound 3; then compound 2.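

Replacing the hydrogen of the oxime hydroxyl with cyanomethyl, while the rest of compound 1 stays unchanged, gives a 3.0-fold higher number from compound 1 to compound 3 (0.48 log units; beyond the scatter) in this assay. Going by these compounds alone, this is the first measured pair that isolates a single change at this oxygen, and it shows that the position accepts the added cyanomethyl at a modest cost rather than a collapse of inhibition, even though the hydroxyl hydrogen is gone. Nothing available here bears on the reason for this step, so the change in number stands as an observation without an explanation.

Within the data shown here, with only one capping group measured on this core, it remains open whether any cap on this oxygen brings a similar loss or whether the result is particular to cyanomethyl. A plain methyl, a longer chain ending in a nitrile, and a chain carrying an amine or a carboxylic acid would help separate these possibilities, while compound 2 cannot settle the question, since its oxime cap comes with differences elsewhere in the molecule.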